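Amino in place of trifluoromethyl on the shared core

The compounds below may be only part of what the source reports. "The series", "measured", "known", "first", "only" and "open" are said of these compounds alone.

Values in a physicochemical assay for lipophilicity, read by LC-MS (on this read-out higher numbers stand for higher lipophilicity and lower numbers for lower lipophilicity), so far
- compound 1 `FC(F)(F)c1nccc(N[C@H]2CC[C@@H](Nc3ccc4nnc(Br)n4n3)CC2)n1` gives 2.9
- compound 2 `FC(F)(F)c1nccc(N[C@H]2CC[C@@H](Nc3ccc4nnc(C(F)(F)F)n4n3)CC2)n1` gives 3.8

Compound 2 holds the higher of the two numbers, with compound 1 lower by a gap beyond the scatter. Compound 3 `Nc1nnc2ccc(N[C@H]3CC[C@@H](Nc4ccnc(C(F)(F)F)n4)CC3)nn12` has amino in place of trifluoromethyl on an aromatic carbon. Among the measured compounds shown here, only one measured step bears on this site, the modest rise a number 0.90 log units higher from compound 1 to compound 2 (beyond the scatter) for trifluoromethyl in place of bromo. For the measured compounds named here, no amino compound has been measured, so the size rests on that step alone. A fall beyond the scatter and larger than that step is expected, with a number 1.60 log units lower from compound 2 to compound 3 (beyond the scatter) as the estimated step. For compound 3 the estimated value is 2.2 (expected range 1.6 to 2.8).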

Compound 3, distribution coefficient: 1.4
The estimate for compound 3 lay 0.80 log units above the measured number; measured number below the stated range.
By their numbers in this assay, from the lowest: compound 3; then compound 1; then compound 2.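

In this assay this aromatic carbon proves far more sensitive than the trifluoromethyl and bromo pair alone indicated. Amino in place of trifluoromethyl gives a number 2.40 log units lower from compound 2 to compound 3 (beyond the scatter) and amino in place of bromo gives a number 1.50 log units lower from compound 1 to compound 3 (beyond the scatter), both large steps against the modest a number 0.90 log units higher from compound 1 to compound 2 (beyond the scatter). No measurement shown accounts for the size of these falls.

Going by these compounds, whether the fall is specific to amino remains open. A methylamino, dimethylamino or hydroxyl group on this carbon could show how far it extends.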